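Ester series: branching the butyl ester of compound 2

A few compounds are considered here, and "the series" means these few. Any claim that something is new, unique, unknown or untested is made for them only; others in the source may bear on it.

Three esters of the shared core have been measured in an ADME assay on RAW264.7 cells (Mus musculus) for cytotoxicity, read by MTT assay, with a stated time of 24 h; on this read-out higher numbers stand for lower toxicity in this test and lower numbers for higher toxicity in this test. Compound 1 `CC/C=C\C[C@H]1C(=O)C=C[C@H]1CC(=O)OCCC` gives 35 uM; compound 2 `CC/C=C\C[C@H]1C(=O)C=C[C@H]1CC(=O)OCCCC` gives 31 uM; compound 3 `CC/C=C\C[C@H]1C(=O)C=C[C@H]1CC(=O)Oc1ccc(O)cc1` gives 49 uM. Compound 2 stands with the smallest number of the three, but none of the three steps leaves the scatter: a 1.1-fold lower number from compound 1 to compound 2 (0.05 log units; within the scatter) for methyl in place of hydrogen on the chain, a 1.4-fold higher number from compound 1 to compound 3 (0.15 log units; within the scatter) and a 1.6-fold higher number from compound 2 to compound 3 (0.20 log units; within the scatter) for the 4-hydroxyphenyl ester. The read-out has so far been indifferent to what sits on the ester oxygen.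

Compound 4 `CC/C=C\C[C@H]1C(=O)C=C[C@H]1CC(=O)OC(C)CC` differs from compound 2 by sec-butyl in place of butyl on an oxygen next to a carbonyl group. For the measured compounds named here, no measured pair tests a branched chain at this position, so the nearest guide is the chain-lengthening step from compound 1 to compound 2, which stayed within the scatter, and the larger swap to compound 3, which also did. The step of a 1.1-fold higher number from compound 2 to compound 4 (0.03 log units; within the scatter) is therefore expected to lie within the scatter, without a preferred direction. For compound 4 the expected value in this assay is 33 uM, with a range of 17 uM to 65 uM.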

Compound 4, half-maximal toxic concentration: 53 uM
Compound 4: middle estimate off by 1.6-fold (0.21 log units), on the low side; measured number inside the range.
By their numbers in this assay, from the lowest: compounds 2, 1, 3 and 4 (each within the scatter of the next).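

In this assay a branched chain on an oxygen next to a carbonyl group gives a 1.7-fold higher number from compound 2 to compound 4 (0.23 log units; within the scatter) and so stays within the scatter, even though butyl and sec-butyl have the same atoms joined differently. Compound 4 also shows a 1.5-fold higher number from compound 1 to compound 4 (0.18 log units; within the scatter) and a 1.1-fold higher number from compound 3 to compound 4 (0.03 log units; within the scatter), both within the scatter, so the straight-chain, branched and 4-hydroxyphenyl esters cannot be told apart on this read-out, and the position has yet to show any measurable response. No evidence bears on the reason for this result.

Going by these compounds, whether the read-out responds to anything at this position remains open. A tert-butyl ester, a longer chain such as octyl, and esters carrying an amine or a carboxylic acid would test this.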